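The source may hold more compounds than are shown below. What is called first, only, known or untested is meant among the compounds shown, and "the series" means these compounds.

Working notes on the series. In a functional assay on Jurkat cells (Homo sapiens) for cytotoxicity, read by luminescence and CellTiter-Glo, with a stated time of 3 days (a higher number here means a weaker inhibitor, a lower number a stronger inhibitor), compound 1 `O=C(Nc1cc(F)cc(F)c1)c1ccc2cccnc2c1O` gives 430 nM as its half-maximal inhibitory concentration, and compound 2 `N#Cc1ccc(NC(=O)c2ccc3cccnc3c2O)c(F)c1` gives 420 nM on the same read-out. These two values lie within the scatter of each other, so compound 2 stands level with compound 1 and the pair cannot be ranked. Going by the values given here, the two compounds differ in more than one place, so no single-change step between measured compounds is available as a guide.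

The next compound is compound 3 `Cc1cc(C#N)ccc1NC(=O)c1ccc2cccnc2c1O`, which keeps the shared core and the cyano group of compound 2 and alters one substituent. The change is methyl in place of fluoro on an aromatic carbon in a single place, methyl in place of fluoro on an aromatic carbon. Among the compounds with values here, the series holds no measured precedent for this exchange, so the expectation is loose. No shift beyond the scatter is expected in this assay, with only a slight drift towards a higher number. The estimated change is a 1.2-fold higher number from compound 2 to compound 3 (0.08 log units; within the scatter) and it is expected to stay within the scatter. For compound 3 the expected value is 500 nM with an estimated range from 200 nM to 1300 nM in this measurement.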

Compound 3, half-maximal inhibitory concentration: 270 nM
The estimate for compound 3 lay 1.9-fold (0.27 log units) above the measured number; the measured number falls inside the stated range.
By their numbers in this assay, from the lowest: compounds 3, 2 and 1 (each within the scatter of the next).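

In this assay, going by these compounds alone, the exchange of fluoro for methyl on an aromatic carbon, ortho to a large group and meta to a cyano group, gives a 1.6-fold lower number from compound 2 to compound 3 (0.19 log units; within the scatter) and is the only single-change step so far. It shows that, at this position and in this read-out, fluoro and methyl cannot be told apart, so the position accepts either group without a shift beyond the scatter. No measurement at hand accounts for the step or ties it to any property of either group.

The compounds shown leave open how this position responds to groups unlike these two, such as an amine, a methoxy group or a longer chain, and whether a step beyond the scatter can be reached there at all. Within the data shown here, they also leave open what the cyano group contributes, since no single-change step yet replaces it with another group, such as a carboxylic acid, while the methyl or fluoro stays in place.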